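Allyl to butyl on a shared core

The source may report more compounds than this note shows. Statements on the series, on what has been measured and on what is new or still open speak of the compounds shown alone.

Compound 1 `CN1CCN(CCNC(=O)n2c(=O)n(Cc3ccccc3)c3ccccc32)CC1`, compound 2 `C=CCn1c(=O)n(C(=O)NCCN2CCN(C)CC2)c2ccccc21` and compound 3 `COc1ccc2c(c1)n(C(=O)NCCN1CCN(C)CC1)c(=O)n2C(C)C` share one core and were tested in a functional assay for antagonist activity at 5-hydroxytryptamine receptor 4 (Cavia porcellus); a higher number here means a more potent compound, by a factor of ten per unit of this negative logarithm, a lower number a less potent compound. For compound 1 this assay reports only a limit, < 6. For compound 2 it likewise reports only a limit, < 6. For compound 3 too the result is a limit, < 6. Among the compounds with values here, the single step with both ends measured, a step that the two limits leave unreadable from compound 1 to compound 2, cannot be read: both of its ends sit at the limit, as the limit of < 6 in this assay, at which 3 of the 3 values shown sit, records. Compound 4 `CCCCn1c(=O)n(C(=O)NCCN2CCN(C)CC2)c2ccccc21` differs from compound 2 in one place: propyl in place of vinyl on a saturated chain carbon bound to an aromatic nitrogen. No measured step bears on this change, since the only one shown is unreadable. Compound 2 stands at the limit of this assay, and nothing in the data points away from it. The expected step is none beyond the scatter, a step that the limit leaves unreadable from compound 2 to compound 4, with a limit again the likeliest outcome. Compound 4 is therefore estimated at 5.5, within the range from 4.8 to 6.2.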

Compound 4, negative logarithm of the antagonist equilibrium constant: < 6
Compound 4 was reported as a limit; the forecaster's own chance of this, stated with the estimate: 75%; the middle value lies beyond the limit too.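

In this assay compound 4 gives < 6, which is a limit. The steps to compound 4 from compound 2 and from compound 1 therefore cannot be read: the limit of < 6 in this assay, at which 4 of the 4 values shown sit.

The compounds shown leave open whether any of these changes on the shared core alters potency, and by how much.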